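Methyl para to a large group on two azo cores

The compounds below may be only part of what the source reports. "The series", "measured", "known", "first", "only" and "open" are said of these compounds alone.

Measured compounds:
compound 1, `Cc1ccc(/N=N/c2ccc(NCCCN(C)C)cc2)cc1`, 50000 nM
compound 2, `CN(C)CCCNc1ccc(/N=N/c2ccccc2)cc1`, 30000 nM
compound 3, `CN(C)CCCN(/N=N/c1ccccc1)c1ccccc1`, 35000 nM

In an ADME assay on Vero cells (Chlorocebus sabaeus) for cytotoxicity, read by crystal violet staining (on this read-out lower numbers stand for higher toxicity in this test and higher numbers for lower toxicity in this test), compound 1 gives 50000 nM, compound 2 gives 30000 nM and compound 3 gives 35000 nM. Compound 2 and compound 3 are built from the same atoms joined differently; the difference between the two cores is not broken down here, and their two values lie within the scatter of each other.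

From compound 2 to compound 1 the change is methyl in place of hydrogen on an aromatic carbon, giving a 1.7-fold higher number from compound 2 to compound 1 (0.22 log units; within the scatter).

Compound 4, `Cc1ccc(/N=N/N(CCCN(C)C)c2ccccc2)cc1`, has not yet been measured. It differs from compound 3 by methyl in place of hydrogen on an aromatic carbon, the same change as from compound 2 to compound 1. Because a 1.7-fold higher number from compound 2 to compound 1 (0.22 log units; within the scatter) stayed within the scatter, the step from compound 3 to compound 4 is expected to be similar, a 1.4-fold higher number from compound 3 to compound 4 (0.15 log units; within the scatter). Compound 4 is therefore estimated at 50000 nM, between 20000 nM and 120000 nM.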

Compound 4, half-maximal cytotoxic concentration: 100000 nM
Compound 4: the middle estimate sits 2.0-fold (0.30 log units) below what was measured; the range from low to high includes it.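

In this assay, methyl in place of hydrogen gives a 2.9-fold higher number from compound 3 to compound 4 (0.46 log units; beyond the scatter). This step lies beyond the scatter and the earlier one does not, yet the two cannot be told apart in size: the same change on two cores in this assay, a 1.7-fold higher number (0.22 log units; within the scatter) from compound 2 to compound 1 and a 2.9-fold higher number (0.46 log units; beyond the scatter) from compound 3 to compound 4, 1.7-fold (0.23 log units) apart, within the scatter of two such steps So the phenyl to 4-methylphenyl change carried over from one core to the other without a measurable difference, but two cores set no rule for the series and do not fix the size of the step.

The compounds shown leave open whether ethyl, methoxy or chlorine in place of that methyl would give a step of like size on these cores. They also leave open whether a longer chain carrying the amine would alter it.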